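Swapping the Aryl Group on Compound 3: What to Expect

The compounds below may be only part of what the source reports. "The series", "measured", "known", "first", "only" and "open" are said of these compounds alone.

Compound 1: `COc1ccccc1CNc1ncnc2c1ncn2[C@@H]1O[C@H](CO)[C@@H](O)[C@H]1O`; in a functional assay on HL-60 cells (Homo sapiens) for antiproliferative activity, with a stated time of 72 h (on this read-out higher numbers stand for weaker inhibition and lower numbers for stronger inhibition), compound 1 gives 2300 nM.
Compound 2: `OC[C@H]1O[C@@H](n2cnc3c(NCc4ccc(Cl)c(Cl)c4)ncnc32)[C@H](O)[C@@H]1O`; in this assay compound 2 gives 2000 nM.
Compound 3: `OC[C@H]1O[C@@H](n2cnc3c(NCc4ccc(F)cc4F)ncnc32)[C@H](O)[C@@H]1O`; in this assay compound 3 gives 3400 nM.

Compound 3 has the highest of the three numbers, but its separation from the others is small: compound 1 lies nearest, as a 1.5-fold higher number from compound 1 to compound 3 (0.17 log units; within the scatter) shows, and compound 2 furthest, as a 1.7-fold higher number from compound 2 to compound 3 (0.23 log units; within the scatter) shows, both steps within the scatter. The three compounds share one core and differ only in the aryl group carried on the saturated chain carbon bound to a nitrogen on the aromatic ring, and none of the swaps among them moved the number beyond the scatter, the third being a 1.2-fold lower number from compound 1 to compound 2 (0.06 log units; within the scatter).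

Compound 4, `Cc1ccc(O)c(CNc2ncnc3c2ncn3[C@@H]2O[C@H](CO)[C@@H](O)[C@H]2O)c1`, continues this series with the change (2-hydroxy-5-methylphenyl in place of 2,4-difluorophenyl on a saturated chain carbon bound to a nitrogen on an aromatic ring). Among the measured compounds shown here, the closest precedent is compound 1, whose 2-methoxyphenyl also carries an oxygen on the ring and which stands within the scatter of compound 3 in this assay. Since every measured aryl exchange at this position stayed within the scatter, compound 4 is expected to show a 1.4-fold lower number from compound 3 to compound 4 (0.13 log units; within the scatter), that is, no step beyond the scatter. The estimate for compound 4 in this assay is therefore 2500 nM, with a range from 1100 nM to 5500 nM.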

Compound 4, half-maximal inhibitory concentration: 15000 nM
Beside the measured number, compound 4's estimate is 6.0-fold (0.78 log units) below it; measured number above the stated range.
By their numbers in this assay, from the lowest: compounds 2, 1 and 3 (each within the scatter of the next); then compound 4.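

Among the compounds shown here, the aryl position on the saturated chain carbon bound to a nitrogen on the aromatic ring proved less tolerant in this assay than the earlier compounds suggested, since 2-hydroxy-5-methylphenyl gave the first steps beyond the scatter: (a 4.4-fold higher number from compound 3 to compound 4 (0.64 log units; beyond the scatter)), (a 7.5-fold higher number from compound 2 to compound 4 (0.88 log units; beyond the scatter)) and (a 6.5-fold higher number from compound 1 to compound 4 (0.81 log units; beyond the scatter)). For the compounds shown here, all three steps point the same way, so the weakening holds against the 2,4-difluorophenyl, 3,4-dichlorophenyl and 2-methoxyphenyl groups alike, and an oxygen on the ring, present in both compound 1 and compound 4, does not by itself keep the number within the scatter of the earlier compounds. No measurement shown here accounts for the loss, so its cause remains unestablished.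

The compounds shown do not separate the contributions of the hydroxy and methyl groups, which enter together in compound 4, so a 2-hydroxyphenyl group without the methyl, or a 3-methylphenyl group without the hydroxy, would be needed to tell them apart. Also open, as far as these compounds go, is how this position responds to an aminophenyl group, a carboxyphenyl group or a longer chain between the nitrogen and the aryl ring.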